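The compounds below may be only part of what the source reports. "The series", "measured", "known", "first", "only" and "open" are said of these compounds alone.

Measured compounds:
Compound 1 `CCCc1ccc(NC2=CC(=O)c3nc4n(c3C2=O)[C@H]2OC[C@@H](O)[C@H]2OC4)cc1` gives only a limit in a functional assay on ECa-109 cells for inhibition, with ECa-109 cell line (Homo sapiens) as the target, read by sulforhodamine B assay (on this read-out higher numbers stand for weaker inhibition and lower numbers for stronger inhibition), > 4000 nM.
Compound 2 `O=C1C(Nc2ccccc2)=CC(=O)c2c1nc1n2[C@H]2OC[C@@H](O)[C@H]2OC1` gives 3560 nM in this assay.
Compound 3 `CCc1ccc(NC2=CC(=O)c3c(nc4n3[C@H]3OC[C@@H](O)[C@H]3OC4)C2=O)cc1` gives only a limit in this assay, > 4000 nM.

Compound 1 thus stands at the limit of this assay, where two of the three values shown sit (the limit of > 4000 nM in this assay, at which 2 of the 3 values shown sit). For the measured compounds named here, the single measured step, an at least 1.1-fold higher number from compound 2 to compound 3 (0.05 log units; that floor lies within the scatter), puts ethyl in place of hydrogen on an aromatic carbon and lies within the scatter. Compound 4 `O=C1C=C(Nc2ccc(Br)cc2)C(=O)c2c1nc1n2[C@H]2OC[C@@H](O)[C@H]2OC1` differs from compound 1 by bromo in place of propyl on an aromatic carbon. Going by the values given here, no measured step swaps propyl for bromo, so the step from compound 2 to compound 3 only shows that an alkyl group at an aromatic carbon changed little; it says nothing about bromo. Compound 2 carries hydrogen where compound 1 carries propyl, and compound 2 gives a number while compound 1 gives a limit, so the shared core without a substituent already inhibits weakly. Compound 4 is therefore expected to stay in that weak region, with an estimated 3800 nM and a range from 1500 nM to 10000 nM. The step of an at least 1.0-fold lower number from compound 1 to compound 4 (0.02 log units; that floor lies within the scatter) is expected to be none beyond the scatter.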

Compound 4, half-maximal inhibitory concentration: 2850 nM
Beside the measured number, compound 4's estimate is 1.3-fold (0.12 log units) above it, within the range that was stated.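

With bromo in place of propyl on the aromatic carbon para to a large group, this assay gives an at least 1.4-fold lower number from compound 1 to compound 4 (0.14 log units; that floor lies within the scatter), so this change is not shown to lower the number beyond the scatter. On these data alone, what is new is that a substituted ring at this position returns a number rather than a limit, which neither the propyl nor the ethyl compound did: the limit of > 4000 nM in this assay, at which 2 of the 4 values shown sit. Compound 1 gives > 4000 nM, which is a limit and not a number, so the true size of the step stays unknown.

The compounds shown leave open whether chloro, fluoro, an amine or a carboxylic acid at this position would move the number beyond the scatter. They also leave open how far the propyl compound really lies from the bromo compound.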